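This account rests on a few compounds, and the source may have more. Where it says the series, first, only, none or still open, it means among the compounds named here.

Three amides that share one core have been measured in a functional assay on HepG2 cells (Homo sapiens) for antiproliferative activity, read by CCK-8 assay, with a stated time of 72 h (on this read-out lower numbers stand for stronger inhibition and higher numbers for weaker inhibition), and they differ only in the aryl group on the carbonyl carbon. Compound 1 `Cc1ccccc1C(=O)Nc1cccc(-c2oc3cc(-c4ccc(F)cc4)ccc3c(=O)c2O)c1` gives 19400 nM in this assay. Compound 2 `O=C(Nc1cccc(-c2oc3cc(-c4ccc(F)cc4)ccc3c(=O)c2O)c1)c1cccc(F)c1` gives 15500 nM, and compound 3 `CCc1ccc(C(=O)Nc2cccc(-c3oc4cc(-c5ccc(F)cc5)ccc4c(=O)c3O)c2)cc1` gives 20600 nM. Compound 1 holds the second highest of the three numbers; its nearest neighbour is compound 3 and its furthest is compound 2, and both gaps sit within the scatter.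

Compound 4 `O=C(Nc1cccc(-c2oc3cc(-c4ccc(F)cc4)ccc3c(=O)c2O)c1)c1cnc(Cl)nc1Cl` has not yet been measured. Relative to compound 1 it carries 2,4-dichloropyrimidin-5-yl in place of 2-methylphenyl on a carbonyl carbon. The three measured steps all concern the same place. There is a 1.3-fold lower number from compound 1 to compound 2 (0.10 log units; within the scatter), there is a 1.1-fold higher number from compound 1 to compound 3 (0.03 log units; within the scatter), and there is a 1.3-fold higher number from compound 2 to compound 3 (0.12 log units; within the scatter). None of them moves the number beyond the scatter, so swapping one aryl group for another on this carbonyl carbon has so far left the read-out where it was.

Compound 4 is therefore expected to land near the measured trio, with no step beyond the scatter, although a ring with two hetero atoms and two chlorines has not been tried before here. The expected step is a 1.1-fold lower number from compound 1 to compound 4 (0.03 log units; within the scatter). The estimate for compound 4 is 18000 nM, within a range from 7000 nM to 45000 nM.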

Compound 4, half-maximal inhibitory concentration: > 100000 nM
Compound 4 ended at the assay's limit; the forecaster's own chance of this, stated with the estimate: 10%; middle value at least 5.5-fold (0.74 log units) from the limit.
By their numbers in this assay, from the lowest: compounds 2, 1 and 3 (each within the scatter of the next). At a limit, above all of these: compound 4.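

Compound 4's reading in this assay is a limit of the assay and not a number: the limit of > 100000 nM in this assay, at which 1 of the 4 values shown sits.

Going by these compounds alone, it shows that this place on the carbonyl carbon is not indifferent to the group it carries, as the earlier compounds had suggested: there is an at least 5.1-fold higher number from compound 1 to compound 4 (0.71 log units; beyond the scatter), there is an at least 4.8-fold higher number from compound 3 to compound 4 (0.68 log units; beyond the scatter), and there is an at least 6.4-fold higher number from compound 2 to compound 4 (0.80 log units; beyond the scatter). Among the compounds shown, the read-out stayed within the scatter only across the three groups with a six-membered aromatic ring of carbon only (2-methylphenyl, 3-fluorophenyl and 4-ethylphenyl), and it left that range with the first ring that holds hetero atoms, 2,4-dichloropyrimidin-5-yl.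

That single change brings in the ring nitrogens and the two chlorines together, so the compounds shown cannot say which of them goes with the loss; a plain pyrimidin-5-yl or a 2,4-dichlorophenyl group would separate the two. They also leave open how far the number of compound 4 lies past the limit, and whether any group on this carbonyl carbon, such as an aminophenyl or a carboxyphenyl ring, could move the number lower than the measured trio.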